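Amide-nitrogen variants of the shared core

A few compounds are considered here, and "the series" means these few. Any claim that something is new, unique, unknown or untested is made for them only; others in the source may bear on it.

Among the compounds with values here, compound 1 `CCOC(=O)C1=C(C)NC(C)=C(C(=O)OCC)C1c1ccc(OCC(=O)NCc2ccccc2)cc1` is the parent of this small set; in a functional assay on the whole organism (strain Wistar) for inhibition, with Rattus norvegicus as the target, read by paw edema, with stated times of 30 min and 0.5 h, at a dose of 20 mg/kg (a lower number here means less inhibition, a higher number more inhibition at the dose given (going by the name of the read-out)), compound 1 gives 8.33%, the lowest of the three numbers measured so far. Compound 2 `CCOC(=O)C1=C(C)NC(C)=C(C(=O)OCC)C1c1ccc(OCC(=O)NNC(=O)c2ccc(C)cc2)cc1` gives 16.7%, and compound 3 `CCOC(=O)C1=C(C)NC(C)=C(C(=O)OCC)C1c1ccc(OCC(=O)NNC(=O)c2cccs2)cc1` gives 44%. The two measured steps from the parent differ sharply: a number 8.4 percentage points higher from compound 1 to compound 2 (within the scatter), whereas a number 35.7 percentage points higher from compound 1 to compound 3 (beyond the scatter). Between those two, a number 27.3 percentage points higher from compound 2 to compound 3 (beyond the scatter). As far as these compounds go, compound 4 `CCOC(=O)C1=C(C)NC(C)=C(C(=O)OCC)C1c1ccc(OCC(=O)NNC(=O)c2ccsc2Cl)cc1` is untested; relative to compound 1 it carries a group of 9 heavy atoms (5 carbon, 1 nitrogen, 1 oxygen, 1 sulfur, 1 chlorine; one five-membered aromatic ring with 1 hetero atom) in place of a group of 7 heavy atoms (7 carbon; one six-membered aromatic ring of carbon only), on an amide-type nitrogen. Within the data shown here, compound 4 resembles compound 3, whose step a number 35.7 percentage points higher from compound 1 to compound 3 (beyond the scatter) bears most on it, so an upward step beyond the scatter is expected, though the chlorine is a part no measured compound carries. The expected step is a number 29.7 percentage points higher from compound 1 to compound 4 (beyond the scatter). Compound 4 is estimated to give 38%, within 15% to 60%.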

Compound 4, a percentage reported as inhibition, in the whole organism at one dose (the size of the read-out at that dose, not a potency): 12.9%
Compound 4: middle estimate off by 25.1 percentage points, on the high side; measured number outside the range, below it.
By their numbers in this assay, from the lowest: compounds 1, 4 and 2 (each within the scatter of the next); then compound 3.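

On a carbonyl carbon, 2-chlorothiophen-3-yl in place of thiophen-2-yl gives a number 31.1 percentage points lower from compound 3 to compound 4 (beyond the scatter) in this assay, so a five-membered aromatic ring with 1 hetero atom does not by itself bring the high number of compound 3. The other steps, a number 4.6 percentage points higher from compound 1 to compound 4 (within the scatter) and a number 3.8 percentage points lower from compound 2 to compound 4 (within the scatter), leave compound 4 level with the benzyl parent and the 4-methylphenyl compound, and compound 3 alone stands apart. No measurement here gives a reason for this drop.

Compound 4 differs from compound 3 in both the chlorine and the point of ring attachment, and these two changes remain unseparated. A thiophen-3-yl group carrying no chlorine would part them.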